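A few compounds are considered here, and "the series" means these few. Any claim that something is new, unique, unknown or untested is made for them only; others in the source may bear on it.

Measured in a functional assay on HEK293 cells for agonist activity at 5-hydroxytryptamine receptor 7 (Homo sapiens), read by cAMP accumulation, with a stated time of 30 min; a higher number here means a larger maximal response, a lower number a smaller maximal response:
compound 1, `COc1ccccc1-c1cc(C2CCNC2)ccc1Cl`: 29%
compound 2, `CCNCc1ccc(Cl)c(-c2ccccc2OC)c1`: 71%
compound 3, `COc1ccccc1-c1cc(CN(C)C)ccc1Cl`: 11%

Compound 3 stands lowest of the three; the step of a number 18 percentage points lower from compound 1 to compound 3 (beyond the scatter) is modest, the step of a number 60 percentage points lower from compound 2 to compound 3 (beyond the scatter) is large. Compound 4, `CCN(CC)Cc1ccc(Cl)c(-c2ccccc2OC)c1`, has not been measured. Its change from compound 3 is diethylamino in place of dimethylamino on a saturated chain carbon bound to an aromatic carbon. The step that bears on it is a number 60 percentage points lower from compound 2 to compound 3 (beyond the scatter), where a secondary amine went to a tertiary one; compound 4 keeps the tertiary amine and only lengthens both chains, so no return toward compound 2 is assumed, and any rise beyond the scatter is uncertain. The expected step is a number 9 percentage points higher from compound 3 to compound 4 (within the scatter). Compound 4 is estimated at 20%, within 5% to 45%.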

Compound 4, largest response reached (Emax), in percent of the reference or control that the assay uses: "not active" (no number reported)
The entry for compound 4 holds no number, so the estimate cannot be set against anything.
By their numbers in this assay, from the lowest: compound 3; then compound 1; then compound 2.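

Going by these compounds alone, compound 4 is recorded as "not active" with no number in this assay, so no step from compound 3 can be read. Nothing shown bears on this result. The compounds shown leave open whether diethylamino and dimethylamino differ in maximal response.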